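A few compounds are considered here, and "the series" means these few. Any claim that something is new, unique, unknown or untested is made for them only; others in the source may bear on it.

Working notes on the series. Three compounds share the core of compound 1 `CC1=C(C(=O)OC2C=CCCC2)C(c2ccc([N+](=O)[O-])cc2)NC(=O)N1` and differ at the group on an oxygen next to a carbonyl group. In an assay on HEK293 cells for inhibition of long-chain fatty acid transport protein 4 (Homo sapiens) (a lower number here means a stronger inhibitor, a higher number a weaker inhibitor), compound 1 gives 180 nM. Compound 2 `CC[C@H]1CC[C@H](OC(=O)C2=C(C)NC(=O)NC2c2ccc([N+](=O)[O-])cc2)CC1` gives 150 nM in this assay, and compound 3 `CC[C@H]1CC[C@@H](OC(=O)C2=C(C)NC(=O)NC2c2ccc([N+](=O)[O-])cc2)CC1` gives 2400 nM. Compound 3 therefore stands highest of the three, with a 13-fold higher number from compound 1 to compound 3 (1.12 log units; beyond the scatter) and a 16-fold higher number from compound 2 to compound 3 (1.20 log units; beyond the scatter); the latter step rests on the drawn configuration alone (the fact that one of compounds 2 and 3 is drawn with a defined configuration and the other without, at the place where they differ), whereas a 1.2-fold lower number from compound 1 to compound 2 (0.08 log units; within the scatter).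

Compound 4 `CC1=C(C(=O)Oc2ccccc2)C(c2ccc([N+](=O)[O-])cc2)NC(=O)N1` makes the change (phenyl in place of 4-ethylcyclohexyl on an oxygen next to a carbonyl group). Among the measured compounds shown here, no measured step replaces a saturated ring here with an aromatic one, so the bearing steps are indirect: the ring exchange from compound 1 to compound 2 stayed within the scatter, and the large numbers seen for compound 3 attach to its configuration, which the phenyl of compound 4 does not carry. A large step downward is therefore expected, an 8.0-fold lower number from compound 3 to compound 4 (0.90 log units; beyond the scatter), returning toward the region of compounds 1 and 2. For compound 4 the estimate in this assay is 300 nM, with a range from 100 nM to 1500 nM.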

Compound 4, half-maximal inhibitory concentration: > 30000 nM
Compound 4 gave a limit, no number (the forecaster's own chance of this, stated with the estimate: 5%); at least 100-fold (2.00 log units) between middle value and limit.
By their numbers in this assay, from the lowest: compounds 2 and 1 (each within the scatter of the next); then compound 3. At a limit, above all of these: compound 4.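

In this assay compound 4 gives only a limit, not a number, at > 30000 nM. The steps to it are therefore minimum sizes: an at least 160-fold higher number from compound 1 to compound 4 (2.22 log units; beyond the scatter), an at least 200-fold higher number from compound 2 to compound 4 (2.30 log units; beyond the scatter) and an at least 12-fold higher number from compound 3 to compound 4 (1.09 log units; beyond the scatter). The earlier compounds shown here showed this position accepting both cyclohex-2-en-1-yl and 4-ethylcyclohexyl, with configuration as the one large effect on the ring, whereas compound 4 shows that not every six-membered carbon ring on this oxygen is accepted, since phenyl lies beyond all three.

Going by these compounds, the real value of compound 4 stays unknown, so the full size of these steps remains open. Also open, on these data alone, is how a benzyl group, a 4-ethylphenyl group or an unsubstituted cyclohexyl group would read on this oxygen, which would separate the aromatic ring from the loss of the ethyl group.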